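This account rests on a few compounds, and the source may have more. Where it says the series, first, only, none or still open, it means among the compounds named here.

Compound 1 `c1ccc2c(c1)CN[C@@H](CN(CCCCNCc1ccncc1)[C@H]1CCCc3cccnc31)C2` in a functional assay on cells for agonist activity at C-X-C chemokine receptor type 4 (Homo sapiens), read by fluorescence and calcium flux, with a stated time of 90 s (a higher number here means that more compound is needed for the effect, a lower number that less compound is needed), gives > 30000 nM, a limit of the assay. Compound 2 `c1ccc2c(c1)CN[C@@H](CN(CCCCNCC1CCCCC1)[C@H]1CCCc3cccnc31)C2` in this assay gives > 30000 nM, also a limit.

Compound 2 therefore stands at the limit of > 30000 nM in this assay, at which 2 of the 2 values shown sit, with no number of its own. Compound 3 `c1ccc2c(c1)CN[C@@H](CN(CCCCNCC1CCOCC1)[C@H]1CCCc3cccnc31)C2` differs from it by oxan-4-yl in place of cyclohexyl on a saturated chain carbon bound to an amine nitrogen. Among the measured compounds shown here, the only measured step, a step that the two limits leave unreadable from compound 1 to compound 2, is itself unreadable between two limits, so it gives no size to carry over. With both neighbours at the limit, compound 3 is expected to stay there as well, a step that the limit leaves unreadable from compound 2 to compound 3. Compound 3 is estimated at 40000 nM, between 10000 nM and 200000 nM.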

Compound 3, half-maximal effective concentration: > 30000 nM
Compound 3: only a limit was reported; the forecaster's own chance of this, stated with the estimate: 85%; the middle value is on the limit's open side.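

Among the compounds shown here, no step among compound 1, compound 2 and compound 3 can be read, as all three stand at the same point: the limit of > 30000 nM in this assay, at which 3 of the 3 values shown sit. The compounds shown leave open whether pyridin-4-yl, cyclohexyl and oxan-4-yl differ at all in this assay and what change to the shared core would give a readable value.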